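Aromatic halogen exchange: chloro to iodo in the series

The compounds below may be only part of what the source reports. "The series", "measured", "known", "first", "only" and "open" are said of these compounds alone.

Of the compounds shown here, two have been measured. Compound 1 `O=C(CCCCCCC(=O)Nc1ccc(C(F)(F)F)cc1)NO` carries trifluoromethyl on the aromatic carbon; in a functional assay on HT-29 cells (Homo sapiens) for antiproliferative activity, with a stated time of 48 h (on this read-out higher numbers stand for an effect only at larger amounts of compound and lower numbers for an effect already at smaller amounts), compound 1 gives 1400 nM. Compound 2 `O=C(CCCCCCC(=O)Nc1ccc(Cl)cc1)NO` carries chloro there instead, and in this assay compound 2 gives 2100 nM. The step of a 1.5-fold higher number from compound 1 to compound 2 (0.18 log units; within the scatter) is within the scatter, so the two numbers do not separate compound 2 from compound 1; compound 2 stands alongside compound 1 rather than apart from it. Compound 3 `O=C(CCCCCCC(=O)Nc1ccc(I)cc1)NO` differs from compound 2 only by iodo in place of chloro on an aromatic carbon. Among the compounds with values here, the single measured step bears on it only loosely: it exchanged two different groups at the same place and moved the number within the scatter. Within the data shown here, no measured step exchanges one halogen for another. A step of similar size, within the scatter, is therefore expected in this assay for compound 3, namely a 1.2-fold lower number from compound 2 to compound 3 (0.07 log units; within the scatter) as the expected step. Compound 3 is estimated at 1800 nM, in the range 700 nM to 4500 nM.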

Compound 3, half-maximal effective concentration: 950 nM
The estimate for compound 3 lay 1.9-fold (0.28 log units) above the measured number; measured number inside the range.
By their numbers in this assay, from the lowest: compounds 3, 1 and 2 (each within the scatter of the next, the first and the last beyond it).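

Within the data shown here, at this place on the aromatic carbon, iodo in place of chloro gives a 2.2-fold lower number from compound 2 to compound 3 (0.34 log units; beyond the scatter) in this assay, a modest step and the only one so far that lies beyond the scatter. The exchange of one halogen for another therefore moves the number measurably here, which the earlier exchange of trifluoromethyl for chloro did not show. Iodo and trifluoromethyl, however, remain unseparated, with a 1.5-fold lower number from compound 1 to compound 3 (0.17 log units; within the scatter). Nothing at hand accounts for the difference between chloro and iodo.

A single exchange between two halogens does not establish a trend, and the compounds shown leave open where bromo or fluoro on the same aromatic carbon would fall. They also leave open whether an amine or a carboxylic acid at this place would keep the number in the same range.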